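The source may hold more compounds than are shown below. What is called first, only, known or untested is meant among the compounds shown, and "the series" means these compounds.

Compound 1 `CCc1cc2ccccc2nc1-c1cc(-c2ccccc2)no1` carries an ethyl group on the shared core. In a functional assay on A549 cells (Homo sapiens) for inhibition, read by MTT assay, with a stated time of 24 h (a lower number here means a stronger inhibitor, a higher number a weaker inhibitor), compound 1 gives only a limit, > 100000 nM. Compound 2 `CCc1cc2ccccc2nc1-c1cc(-c2ccc(F)cc2)no1` differs from it by fluoro in place of hydrogen on an aromatic carbon. In this assay compound 2 likewise gives only a limit, > 100000 nM. The step that the two limits leave unreadable from compound 1 to compound 2 thus cannot be read, as the limit of > 100000 nM in this assay, at which 2 of the 2 values shown sit, shows. Compound 2 therefore stands at the limit of this assay, with no number attached to it.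

Compound 3 `CCCCc1cc2ccccc2nc1-c1cc(-c2ccc(F)cc2)no1` differs from compound 2 by ethyl in place of hydrogen on a saturated chain carbon, two bonds along the chain from an aromatic carbon. No measured step bears on this change; the one step shown, from compound 1 to compound 2, is unreadable. Compound 3 is therefore expected to remain around the limit, the step of a number no higher from compound 2 to compound 3 (the limit leaves the size open) being the estimate. Compound 3 is estimated at 100000 nM, ranging from 30000 nM to 300000 nM.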

Compound 3, half-maximal inhibitory concentration: 27500 nM
The estimate for compound 3 lay 3.6-fold (0.56 log units) above the measured number, and the stated range ends above it.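

Going by these compounds alone, compound 3 is the only one of the three compounds that gives a number rather than a limit, so this is the first change whose effect can be read, unlike the unreadable fluoro step. On a saturated chain carbon, two bonds along the chain from an aromatic carbon, going from ethyl to butyl gives an at least 3.6-fold lower number from compound 2 to compound 3 (0.56 log units; beyond the scatter) in this assay. Compound 2 gives only a limit, so the full size of this step stays open: the limit of > 100000 nM in this assay, at which 2 of the 3 values shown sit.

A single chain change does not show whether a longer chain would lower the number further or whether an amine at the same place would be tolerated. It also leaves open what the fluoro group contributes once the butyl chain is present, and why the number falls.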